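Moving from a seven-membered ring to a five-membered ring

The source may hold more compounds than are shown below. What is called first, only, known or untested is meant among the compounds shown, and "the series" means these compounds.

Values in an ADME assay on microsomes from liver (Homo sapiens) for metabolic stability (a lower number here means slower removal, a higher number faster removal of the compound), for the measured compounds
compound 1 `CC(=O)N[C@@H]1CCC[C@H](C(=O)Nc2cc(-c3cnc4n3CCCC4)c(Cl)cn2)C1` gives 16 mL.min-1.g-1
compound 2 `CC(=O)N[C@@H]1CCC[C@H](C(=O)Nc2cc(-c3cnc4n3CCC4)c(Cl)cn2)C1` gives 9.7 mL.min-1.g-1
compound 3 `CC(=O)N[C@@H]1CCC[C@H](C(=O)Nc2cc(-c3cnn4c3CCCCC4)c(Cl)cn2)C1` gives 39 mL.min-1.g-1

Compound 3 holds the highest number of the three. The steps of a 2.4-fold higher number from compound 1 to compound 3 (0.39 log units; beyond the scatter) and a 4.0-fold higher number from compound 2 to compound 3 (0.60 log units; beyond the scatter) both end at this highest value. Compound 4 `CC(=O)N[C@@H]1CCC[C@H](C(=O)Nc2cc(-c3cnc4n3CC(C)(C)C4)c(Cl)cn2)C1` has not yet been measured. It has the same atoms as compound 3, joined differently, and the change is a group of 10 heavy atoms (8 carbon, 2 nitrogen; one five-membered non-aromatic ring with 1 hetero atom, one five-membered aromatic ring with 2 hetero atoms) in place of a group of 10 heavy atoms (8 carbon, 2 nitrogen; one five-membered aromatic ring with 2 hetero atoms, one seven-membered non-aromatic ring with 1 hetero atom), on an aromatic carbon in the shared core. The entering group has the ring sizes found in compound 2 but the heavy-atom total of compound 3, so neither compound is an exact guide. The closest measured evidence is a 4.0-fold higher number from compound 2 to compound 3 (0.60 log units; beyond the scatter) when read in reverse, as a move away from the seven-membered non-aromatic ring. The step of a 1.6-fold lower number from compound 1 to compound 2 (0.22 log units; within the scatter) also ends at a five-membered non-aromatic ring and stays within the scatter. Compound 1 and compound 2, which both lack the seven-membered non-aromatic ring, show lower numbers than compound 3, so a modest fall is expected in this assay for this change. Going by the values given here, no measured compound carries the entering group itself, so only part of the largest step is expected to return. The estimated step is a 2.2-fold lower number from compound 3 to compound 4 (0.34 log units; beyond the scatter) and remains an expectation. Compound 4 is estimated at 18 mL.min-1.g-1 with an expected range from 9 mL.min-1.g-1 to 36 mL.min-1.g-1 in this measurement.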

Compound 4, intrinsic clearance in microsomes: 63 mL.min-1.g-1
Compound 4: the middle estimate sits 3.5-fold (0.54 log units) below what was measured, and the stated range ends below it.
By their numbers in this assay, from the lowest: compounds 2 and 1 (each within the scatter of the next); then compounds 3 and 4 (each within the scatter of the next).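

In this assay, the five-membered non-aromatic ring does not by itself keep the number low: with the ring sizes of compound 2 retained, the group of 10 heavy atoms gives a clear rise (a 6.5-fold higher number from compound 2 to compound 4 (0.81 log units; beyond the scatter)). The same group also stands clear of the six-membered ring of compound 1 (a 3.9-fold higher number from compound 1 to compound 4 (0.60 log units; beyond the scatter)), yet it cannot be told apart from the seven-membered ring carrying the same atoms (a 1.6-fold higher number from compound 3 to compound 4 (0.21 log units; within the scatter)). Among these four compounds, both groups of 10 heavy atoms therefore stand beyond the scatter above the two smaller groups, with no compound going against this, and nothing available here bears on the reason for it.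

The compounds shown leave open whether this rise follows the total size of the group or the particular place of the additional carbons on the five-membered non-aromatic ring. They also leave open how the number would move if an ether oxygen or a fluoro group stood on that ring instead of those carbons.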